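Swapping an acetamide-bearing ring for a methanesulfonamide-bearing ring

A few compounds are considered here, and "the series" means these few. Any claim that something is new, unique, unknown or untested is made for them only; others in the source may bear on it.

Of the compounds shown here, three have been tested in a functional assay on blood for antagonist activity at thromboxane A2 receptor (Homo sapiens); on this read-out higher numbers stand for weaker binding and lower numbers for tighter binding. Compound 1, `O=C(O)CC/C=C\CO[C@H]1C(OCc2ccc(-c3ccccc3)cc2)CC[C@@H]1N1CCCCC1`, was measured twice and gave 63.1 nM; 15.9 nM (2 entries); the spread between these two runs, recorded as the several entries of compound 1 in this assay, 63.1 nM; 15.9 nM (2 entries), shows how much a single measurement of this kind can move, so compound 1 carries no single number. Compound 2, `NC(=O)Cc1ccccc1-c1ccc(COC2CC[C@H](N3CCCCCC3)[C@H]2OC/C=C\CCC(=O)O)cc1`, gives 7.94 nM in this assay, and compound 3, `O=C(O)CC/C=C\CO[C@H]1[C@@H](OCc2ccc(-c3ccccc3)cc2)CC[C@@H]1N1CCCCCC1`, gives 5.01 nM; these two values lie within the usual scatter of each other, so no order between them can be claimed.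

Compound 4, `CS(=O)(=O)Nc1cccc(-c2ccc(COC3CC[C@H](N4CCCCCC4)[C@H]3OC/C=C\CCC(=O)O)cc2)c1`, differs from compound 2 in a single place: a group of 11 heavy atoms (7 carbon, 1 nitrogen, 2 oxygen, 1 sulfur; one six-membered aromatic ring of carbon only) in place of a group of 10 heavy atoms (8 carbon, 1 nitrogen, 1 oxygen; one six-membered aromatic ring of carbon only), on an aromatic carbon. Going by the values given here, no pair of measured compounds differing only at this position is available, so the size and direction of this step cannot be read off from the data. With the shared core untouched and the change confined to one aromatic ring, the expectation is that compound 4 stays close to compound 2, the step from compound 2 to compound 4 being estimated at a 1.3-fold lower number from compound 2 to compound 4 (0.10 log units; within the scatter), which does not clearly exceed the scatter. Compound 4 is therefore expected to give about 6.3 nM in this assay, within a range from 2 nM to 25 nM.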

Compound 4, dissociation constant: 12.6 nM
Compound 4: middle estimate off by 2.0-fold (0.30 log units), on the low side, and the stated range covers the measured number.
By their numbers in this assay, from the lowest: compounds 3, 2 and 4 (each within the scatter of the next, the first and the last beyond it).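

In this assay, exchanging the acetamide-bearing ring for 3-(methanesulfonamido)phenyl gives a 1.6-fold higher number from compound 2 to compound 4 (0.20 log units; within the scatter). Going by these compounds alone, this is the first direct reading at this position, which sits on an aromatic carbon at the far end of the large group, and it shows that this swap leaves the number within the scatter even though the entering group brings a sulfur atom and one more hydrogen-bond acceptor. The step is small enough that it should not be read as a real loss, because a repeated measurement in this series can move by more than this step does: the several entries of compound 1 in this assay, 63.1 nM; 15.9 nM (2 entries)

The two compounds do not separate the effect of the side group itself from the effect of where it sits on the ring, since the swap changes the ring as a whole. From the compounds shown here alone, whether a plain amine or a carboxylic acid on this ring would also stay within the scatter remains open, as does whether this position accepts such groups at all or only neutral ones like the two compared here.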